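The compounds below may be only part of what the source reports. "The series", "measured", "known", "first", "only" and "open" are said of these compounds alone.

Measured compounds in an ADME assay on HUVEC cells (Homo sapiens) for cytotoxicity, read by MTT assay, with a stated time of 72 h; a lower number here means a stronger inhibitor, a higher number a weaker inhibitor:
compound 1 `O=C(CCC(=O)OCCCCCCSc1ccc([N+](=O)[O-])c2nonc12)Nc1ccccc1F` gives 840 nM
compound 2 `COc1ccccc1NC(=O)CCC(=O)OCCCCCCSc1ccc([N+](=O)[O-])c2nonc12` gives 1610 nM
compound 3 `Cc1ccc(NC(=O)CCC(=O)OCCCCCCSc2ccc([N+](=O)[O-])c3nonc23)cc1` gives 2340 nM

Compound 3 has the highest number of the three; its nearest neighbour is compound 2, and its furthest is compound 1, with a 2.8-fold higher number from compound 1 to compound 3 (0.44 log units; beyond the scatter) beyond the scatter. Compound 4 `O=C(CCC(=O)N1CCCCC1)OCCCCCCSc1ccc([N+](=O)[O-])c2nonc12` differs from compound 3 in one place: piperidin-1-yl in place of (4-methylphenyl)amino on a carbonyl carbon. Among the compounds with values here, no measured step makes this kind of exchange; the known steps only alter the aromatic group on the amide-type nitrogen, as in a 1.9-fold higher number from compound 1 to compound 2 (0.28 log units; within the scatter) and a 1.5-fold higher number from compound 2 to compound 3 (0.16 log units; within the scatter), both within the scatter. Those small steps give no sign that the amide end moves this read-out much, so from compound 3 to compound 4 no step beyond the scatter is expected, and a 1.1-fold higher number from compound 3 to compound 4 (0.03 log units; within the scatter) is the estimated change. Compound 4 is therefore expected to give about 2500 nM in this assay, within 1000 nM to 6500 nM.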

Compound 4, half-maximal inhibitory concentration: 1990 nM
For compound 4 the middle estimate is 1.3-fold (0.10 log units) above the measured one; low and high end bracket the measured number.
By their numbers in this assay, from the lowest: compounds 1, 2, 4 and 3 (each within the scatter of the next, the first and the last beyond it).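

On a carbonyl carbon, a non-aromatic ring without the amide hydrogen can take the place of an aromatic amine in this assay, and the number stays close to those of two aromatic compounds: piperidin-1-yl gives a 1.2-fold lower number from compound 3 to compound 4 (0.07 log units; within the scatter) and a 1.2-fold higher number from compound 2 to compound 4 (0.09 log units; within the scatter). Only the comparison with the 2-fluorophenyl compound goes beyond the scatter, with a 2.4-fold higher number from compound 1 to compound 4 (0.37 log units; beyond the scatter). No supporting measurement explains these results. Still open, on these data alone, is how a carboxylic acid or a primary amine on this carbonyl carbon would read out. As far as these compounds go, the effect of a longer chain also remains open.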